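Benzylsulfanyl in Place of Methoxyethoxy: Cytotoxicity Outlook

The compounds below may be only part of what the source reports. "The series", "measured", "known", "first", "only" and "open" are said of these compounds alone.

Compound 1, `COCCOc1nc(N)nc2c1ncn2/C=C1/CC1(CO)CO`: a limit of > 300000 nM in an ADME assay on HFF cells (Homo sapiens) for cytotoxicity, with a stated time of 8 days; a lower number here means that less compound is tolerated, a higher number that more compound is tolerated.
Compound 2, `Nc1nc(NC2CCCC2)c2ncn(/C=C3/CC3(CO)CO)c2n1`: a limit of > 300000 nM in this assay.
Compound 3, `Nc1nc(SC2CCCC2)c2ncn(/C=C3/CC3(CO)CO)c2n1`: a limit of > 300000 nM in this assay.

Where compound 1 stands in this assay is thus known only as a limit, not as a number. Compound 4, `Nc1nc(SCc2ccccc2)c2ncn(/C=C3/CC3(CO)CO)c2n1`, differs from compound 1 by benzylsulfanyl in place of 2-methoxyethoxy on an aromatic carbon. The measured steps that bear on this change, a step that the two limits leave unreadable from compound 1 to compound 2, a step that the two limits leave unreadable from compound 1 to compound 3 and a step that the two limits leave unreadable from compound 2 to compound 3, give no readable size because of the limit of > 300000 nM in this assay, at which 3 of the 3 values shown sit. No direction or size of step in this assay can therefore be drawn from them. The expectation is that compound 4 again reaches only the same limit, with an expected step of a number no higher from compound 1 to compound 4 (the limit leaves the size open). Compound 4 is estimated at 300000 nM, between 100000 nM and 300000 nM.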

Compound 4, half-maximal cytotoxic concentration: > 300000 nM
Compound 4: only a limit was reported; the forecaster's own chance of this, stated with the estimate: 85%; the middle value lies on the limit itself.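

Compound 4 yields no readable step from compound 1, compound 2 or compound 3 in this assay, because all of them share one limit: the limit of > 300000 nM in this assay, at which 4 of the 4 values shown sit.

The compounds shown leave open whether these groups on the aromatic carbon differ in the concentration tolerated.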